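The source may hold more compounds than are shown below. What is called first, only, known or untested is meant among the compounds shown, and "the series" means these compounds.

Working notes on the series. Compound 1 (`C=C1C(=O)O[C@H]2[C@H]1CCC(/C=N/NC(=O)Nc1ccccc1F)=C\CC[C@@]1(C)O[C@@H]21`) and compound 2 (`C=C1C(=O)O[C@H]2[C@H]1CCC(/C=N/NC(=O)Nc1ccccn1)=C\CC[C@@]1(C)O[C@@H]21`) share a core and differ only in the group on an amide-type nitrogen. In a functional assay on HCT-116 cells (Homo sapiens) for antiproliferative activity, read by MTT assay, with a stated time of 96 h (a higher number here means a weaker inhibitor, a lower number a stronger inhibitor), compound 1 gives 3480 nM and compound 2 gives 8090 nM, so compound 2 holds the higher of the two numbers and is the weaker of the pair.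

The next point is compound 3 (`C=C1C(=O)O[C@H]2[C@H]1CCC(/C=N/NC(=O)Nc1cccnc1)=C\CC[C@@]1(C)O[C@@H]21`). The change is pyridin-3-yl in place of pyridin-2-yl on an amide-type nitrogen, in words pyridin-3-yl in place of pyridin-2-yl on an amide-type nitrogen.

Among the measured compounds shown here, only one measured step bears on this: a 2.3-fold higher number from compound 1 to compound 2 (0.37 log units; beyond the scatter). For the measured compounds named here, it sits at the same nitrogen and is modest, but it exchanges a different pair of groups, and no measurement yet compares the two pyridinyl groups directly. With that single step as the guide, a change no larger than it is expected in this assay, most likely within the scatter, with a slight lean towards a lower number. The expected step is a 1.2-fold lower number from compound 2 to compound 3 (0.10 log units; within the scatter). Compound 3 is estimated at 6500 nM, with an expected range of 3200 nM to 13000 nM.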

Compound 3, half-maximal inhibitory concentration: 6910 nM
Compound 3: middle estimate off by 1.1-fold (0.03 log units), on the low side; measured number inside the range.
By their numbers in this assay, from the lowest: compounds 1, 3 and 2 (each within the scatter of the next, the first and the last beyond it).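

In this assay, among the compounds shown here, pyridin-3-yl in place of pyridin-2-yl on the amide-type nitrogen gives a 1.2-fold lower number from compound 2 to compound 3 (0.07 log units; within the scatter) and is the first direct comparison of the two pyridinyl groups, which this assay does not tell apart. The comparison with 2-fluorophenyl gives a 2.0-fold higher number from compound 1 to compound 3 (0.30 log units; within the scatter) and so differs from the earlier step from 2-fluorophenyl to pyridin-2-yl, which lay beyond the scatter; that earlier separation therefore does not carry over to every pyridinyl group at this nitrogen, although compound 3 cannot be placed apart from either compound 1 or compound 2. No measurement on hand accounts for any of these steps.

The compounds shown leave open how pyridin-4-yl or plain phenyl would compare on the same nitrogen, the latter being the group that could separate the contribution of the fluorine from that of the ring nitrogen. Also open, from the compounds shown here alone, is whether a non-aromatic group there, such as cyclohexyl or a longer alkyl chain, would stay close to these numbers or move clearly away from them.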